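The source may hold more compounds than are shown below. What is called first, only, known or untested is meant among the compounds shown, and "the series" means these compounds.

Of the compounds shown here, two have been measured in an assay on HEK293 cells for antagonist activity at Toll-like receptor 9 (Homo sapiens), read by spectrophotometry; a lower number here means a stronger inhibitor, a higher number a weaker inhibitor. Compound 1 `CCN1CCN(CCCn2cnc3c(N4CCN(C(=O)C5CCCC5)CC4)nc(NCc4ccc(N(CC)CC)cc4)nc32)CC1` gives 8800 nM in this assay. Compound 2 `CCN1CCN(CCCn2cnc3c(N4CCN(C5CCCC5)CC4)nc(N)nc32)CC1` gives 280 nM in this assay, the lower of the two numbers and beyond the scatter from compound 1. Compound 3 `CCN1CCN(CCCn2cnc3c(N4CCN(C(=O)C5CCCC5)CC4)nc(N)nc32)CC1` has not yet been measured; it differs from compound 2 by cyclopentylcarbonyl in place of cyclopentyl on an amine nitrogen in a ring. Compound 1 also carries a cyclopentylcarbonyl group on an amine nitrogen in a ring but differs in a second place, so it only hints at a direction. Because compound 1 gives 8800 nM, the step from compound 2 to compound 3 is expected to be a weakening of a 5.4-fold higher number from compound 2 to compound 3 (0.73 log units; beyond the scatter), beyond the scatter. Compound 3 is estimated at 1500 nM, within a range of 400 nM to 6000 nM.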

Compound 3, half-maximal inhibitory concentration: > 30000 nM
Compound 3: a limit, no number; the forecaster's own chance of this, stated with the estimate: 5%; at least 20-fold (1.30 log units) between middle value and limit.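

Compound 3 stands at a limit of the assay, not at a number: the limit of > 30000 nM in this assay, at which 1 of the 3 values shown sits. On the amine nitrogen in the ring, cyclopentylcarbonyl in place of cyclopentyl is therefore a large loss when the change is read alone, with an at least 100-fold higher number from compound 2 to compound 3 (2.02 log units; beyond the scatter). With cyclopentylcarbonyl present, 4-(diethylamino)benzyl on the nitrogen on an aromatic ring also counts, since hydrogen in its place gives an at least 3.4-fold higher number from compound 1 to compound 3 (0.53 log units; beyond the scatter).

On these data alone, whether a methyl or an acetyl on the ring nitrogen would behave like cyclopentyl or like cyclopentylcarbonyl remains open. So does what 4-(diethylamino)benzyl would do alongside cyclopentyl.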